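Allyl to prenyl on the piperidine nitrogen, trans styryl series

The source may hold more compounds than are shown below. What is called first, only, known or untested is meant among the compounds shown, and "the series" means these compounds.

Of the compounds shown here, two have numbers so far. Compound 1, `CC(C)=CCN1CCCC(/C=C\c2ccccc2)C1`, gives 1 nM in an assay on isolated protein for binding affinity to Sigma non-opioid intracellular receptor 1 (Rattus norvegicus); a higher number here means a weaker inhibitor, a lower number a stronger inhibitor. Within the data shown here, compound 2, `C=CCN1CCCC(/C=C/c2ccccc2)C1`, gives 4 nM in this assay, which is the higher of the two numbers; the gap to compound 1 is beyond the usual scatter, though the two compounds differ in more than one place, so no single step is read from it. Compound 3, `CC(C)=CCN1CCCC(/C=C/c2ccccc2)C1`, has not been measured. It differs from compound 2 in one place: 2-methylprop-1-en-1-yl in place of vinyl on a saturated chain carbon bound to an amine nitrogen in a ring. The expected step is a modest decrease in the number, beyond the scatter but not large, because compound 1 already shows 1 nM with the same 2-methylprop-1-en-1-yl group in place on a compound of this series. Compound 3 is therefore estimated at 2 nM in this assay, within a range of 0.7 nM to 6 nM, the expected step being a 2.0-fold lower number from compound 2 to compound 3 (0.30 log units; within the scatter).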

Compound 3, half-maximal inhibitory concentration: 38 nM
Beside the measured number, compound 3's estimate is 19-fold (1.28 log units) below it, outside the stated range (above it).
By their numbers in this assay, from the lowest: compound 1; then compound 2; then compound 3.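

In this assay, allyl to 3-methylbut-2-en-1-yl on the E double bond raises the number, a 9.5-fold higher number from compound 2 to compound 3 (0.98 log units; beyond the scatter), so at this position the change costs affinity in the trans styryl series. Compound 1 and compound 3 both carry 3-methylbut-2-en-1-yl, and the larger step, a 38-fold higher number from compound 1 to compound 3 (1.58 log units; beyond the scatter), goes with the double bond drawn Z in compound 1 and E in compound 3, so the low number of compound 1 does not carry over to the E series. The only record bearing on that larger step concerns configuration: the fact that one of compounds 1 and 3 is drawn with a defined configuration and the other without, at the place where they differ

As far as these compounds go, whether allyl to 3-methylbut-2-en-1-yl runs the same way on the Z double bond remains open. Also open, from the compounds shown here alone, is how a saturated chain such as n-butyl, or a benzyl group, would behave at this position.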